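This account rests on a few compounds, and the source may have more. Where it says the series, first, only, none or still open, it means among the compounds named here.

Three compounds have been measured in a functional assay on HCT-116 cells (Homo sapiens) for inhibition, read by sulforhodamine B assay, with a stated time of 48 h; on this read-out lower numbers stand for stronger inhibition of growth and higher numbers for weaker inhibition of growth:

compound 1, `COc1cc(-c2nn(-c3cccc(NC(=O)Nc4cc(C(F)(F)F)cc(C(F)(F)F)c4)c3)cc2-c2ccncc2)ccc1Cl`, gives 643 nM
compound 2, `O=C(Nc1cccc(-n2cc(-c3ccncc3)c(-c3ccc(Cl)c(O)c3)n2)c1)Nc1cc(C(F)(F)F)cc(C(F)(F)F)c1`, gives 428 nM
compound 3, `COc1cc(-c2nn(-c3cccc(NC(=O)Nc4ccc(Cl)c(C(F)(F)F)c4)c3)cc2-c2ccncc2)ccc1Cl`, gives 1170 nM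

Compound 1 and compound 2 differ in one place: hydrogen in place of methyl on an oxygen on an aromatic ring. In this assay that change made a 1.5-fold lower number from compound 1 to compound 2 (0.18 log units; within the scatter), a step that stays within the scatter of repeated measurements, so it is not a clear gain or loss. Compound 3 carries the same methoxy group as compound 1 but has a different urea partner; the difference between the two cores is not broken down here. Compound 3 has the highest of the three numbers, a step from compound 1 that is within the scatter and a step from compound 2 that is beyond it.

Compound 4, `O=C(Nc1cccc(-n2cc(-c3ccncc3)c(-c3ccc(Cl)c(O)c3)n2)c1)Nc1ccc(Cl)c(C(F)(F)F)c1`, has not been measured. It differs from compound 3 in exactly the way compound 2 differs from compound 1: hydrogen in place of methyl on an oxygen on an aromatic ring. The place is described in the same words in both pairs, so this is the same change carried onto the core of compound 3. Going by the values given here, the one earlier example of it gave only a small step, so a similarly small step is expected here, a 1.5-fold lower number from compound 3 to compound 4 (0.18 log units; within the scatter), resting on the single measured pair. Compound 4 is therefore estimated at 780 nM, with a likely range from 350 nM to 1700 nM.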

Compound 4, concentration for 50% growth inhibition: 998 nM
Compound 4: the middle estimate sits 1.3-fold (0.11 log units) below what was measured; the range from low to high includes it.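

Replacing methoxy with hydroxy on the core of compound 3 gave a 1.2-fold lower number from compound 3 to compound 4 (0.07 log units; within the scatter) in this assay. Set beside the earlier example of the same swap, this new step shows that the change carries over from one core to the other with no difference that can be told apart from ordinary measurement noise: the same change on two cores in this assay, a 1.5-fold lower number (0.18 log units; within the scatter) from compound 1 to compound 2 and a 1.2-fold lower number (0.07 log units; within the scatter) from compound 3 to compound 4, 1.3-fold (0.11 log units) apart, within the scatter of two such steps. This shows only that, on these two cores with their two different urea partners, the swap from 4-chloro-3-methoxyphenyl to 4-chloro-3-hydroxyphenyl leaves the growth-inhibition number about where it was; neither step is a clear gain or loss, two pairs cannot establish a rule for the whole series, and they say nothing about why the swap matters so little.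

The compounds shown leave open whether a larger group on that oxygen, such as an ethoxy group or a longer chain, would also leave the number in place, or whether an amine or a carboxylic acid in place of the methoxy group would shift it. They also leave open whether the same small step would appear with a urea partner other than the two seen here.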